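This account rests on a few compounds, and the source may have more. Where it says the series, first, only, none or still open, it means among the compounds named here.

Compound 2, `CCCOC(=O)[C@@]12C[C@@H]1[C@@H](n1cnc3c(NC)nc(C#Cc4ccc(Cl)s4)nc31)[C@H](O)[C@@H]2O`, gives 5.78 nM in an assay on HEK-293T cells for displacement of a labelled ligand from transmembrane domain-containing protein TMIGD3 (Homo sapiens), read by scintillation counting and radioligand binding, with stated times of 10 min and 90 min (on this read-out lower numbers stand for stronger inhibition and higher numbers for weaker inhibition), the lowest of the three numbers recorded there. Its nearest neighbour is compound 3, `CNc1nc(C#Cc2ccc(Cl)s2)nc2c1ncn2[C@H]1[C@H](O)[C@H](O)[C@]2(C(=O)OCCC(C)C)C[C@H]12`, which gives 24.4 nM in this assay; furthest away is compound 1, `CCOC(=O)[C@@]12C[C@@H]1[C@@H](n1cnc3c(NC)nc(C#Cc4ccc(Cl)s4)cc31)[C@H](O)[C@@H]2O`, which gives 169 nM in this assay. The step from compound 2 to compound 3 is the only one that differs in a single place: it reads a 4.2-fold higher number from compound 2 to compound 3 (0.63 log units; beyond the scatter), a modest weakening that lies beyond the scatter.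

Compound 4, `CNc1nc(C#Cc2ccc(Cl)s2)nc2c1ncn2[C@H]1[C@H](O)[C@H](O)[C@]2(C(=O)OCCC3CCCCC3)C[C@H]12`, has not yet been measured in this assay. It departs from compound 2 by cyclohexyl in place of methyl on a saturated chain carbon, two bonds along the chain from an oxygen next to a carbonyl group. This is the same kind of change as the step to compound 3, but the group that enters is larger: a ring rather than a branched chain. Since the smaller enlargement already produced a 4.2-fold higher number from compound 2 to compound 3 (0.63 log units; beyond the scatter), the expectation is a further rise in the number, most likely of similar or somewhat greater size, in the direction of weaker inhibition. On that basis compound 4 is expected to give about 40 nM in this assay, with a plausible range from 10 nM to 160 nM. The step that this estimate implies is expected to read a 6.9-fold higher number from compound 2 to compound 4 (0.84 log units; beyond the scatter).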

Compound 4, inhibition constant: 770 nM
Estimate against measurement, compound 4: 19-fold (1.28 log units) below; the whole stated range lies below it.
By their numbers in this assay, from the lowest: compound 2; then compound 3; then compound 1; then compound 4.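

Compound 4 shows that growth at this saturated chain carbon, two bonds along the chain from an oxygen next to a carbonyl group, can cost far more in this assay than the isopropyl change suggested, with cyclohexyl in place of methyl giving a 130-fold higher number from compound 2 to compound 4 (2.12 log units; beyond the scatter) and thus a large rather than a modest loss. Among the compounds shown here, the larger part of that loss appears on going from isopropyl to cyclohexyl, which gives a 32-fold higher number from compound 3 to compound 4 (1.50 log units; beyond the scatter) and so shows that, across these three compounds, the number rises in the order methyl, isopropyl, cyclohexyl, with no compound going against that order but with an uneven rise. Nothing shown here accounts for this rise.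

With only these three groups at this place, the compounds shown leave open whether the large rise goes with the ring itself or with the number of carbons, which a straight hexyl chain, a cyclopropyl or a phenyl group could help to separate. They also leave open whether a hydroxyl or an amine on the cyclohexyl ring would change the result.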